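Swapping a Sulfonamide for Methoxymethyl on a Shared Core

The source may hold more compounds than are shown below. What is called first, only, known or untested is meant among the compounds shown, and "the series" means these compounds.

Three measured compounds share one core. Compound 1 `CS(=O)(=O)Nc1cccc(C(=O)N2CCCC(C(=O)Nc3ccc(Cl)cc3)C2)c1` carries a methanesulfonamido group on its aromatic ring. In an ADME assay on PC-3 cells (Homo sapiens) for cytotoxicity, read by WST assay, tested at 100 uM (a lower number here means less inhibition, a higher number more inhibition at the concentration tested (going by the name of the read-out)), compound 1 gives 3%. Compound 3 `CCc1cccc(NC(=O)C2CCCN(C(=O)c3cc(C(F)(F)F)cc(C(F)(F)F)c3)C2)c1` gives 0% in this assay, and compound 2 `O=C(Nc1cccc(CN2CCCC2)c1)C1CCCN(C(=O)c2cc(C(F)(F)F)cc(C(F)(F)F)c2)C1` gives 51%. Among these three numbers compound 1 stands second highest: its gap to compound 3 lies within the usual scatter, while compound 2 sits well beyond it. Among the measured compounds shown here, the only measured single-point step is a number 51 percentage points lower from compound 2 to compound 3 (beyond the scatter), and it concerns the anilide side of the molecule, not the ring that changes here.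

Compound 4 `COCc1cccc(C(=O)N2CCCC(C(=O)Nc3ccc(Cl)cc3)C2)c1` is the next step from compound 1: methoxymethyl in place of methanesulfonamido on an aromatic carbon. For the measured compounds named here, no measured pair isolates this change, so its effect is uncharted. Still, the two compounds without a pyrrolidin-1-yl group, compound 1 and compound 3, both sit near zero, and compound 4 also has no such group. The step is therefore expected to stay within the scatter, a number 3 percentage points higher from compound 1 to compound 4 (within the scatter). Compound 4 is estimated at 6%, within -8% to 25%.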

Compound 4, a percentage reported as inhibition, at one concentration (the size of the read-out at that concentration, not a potency): 0%
Compound 4: middle estimate off by 6 percentage points, on the high side; the range from low to high includes it.
By their numbers in this assay, from the lowest: compounds 3, 4 and 1 (each within the scatter of the next); then compound 2.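

In this assay, methoxymethyl in place of methanesulfonamido on this aromatic carbon gives a number 3 percentage points lower from compound 1 to compound 4 (within the scatter) on the core of compound 1. Among the compounds shown here, this pair is the first measured comparison at this position, and it shows that the methanesulfonamido group, with its hydrogen-bond donor, can be exchanged for methoxymethyl, which has none, without a readable change in this read-out. No measurement at hand explains this result.

Because both numbers lie close to zero, this pair cannot show whether any group at this position could raise the number. From the compounds shown here alone, how an amine such as pyrrolidin-1-ylmethyl, a carboxylic acid or a longer chain on this aromatic carbon would behave remains open, and so does whether methoxymethyl would give the same result on a different core.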